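The source may report more compounds than this note shows. Statements on the series, on what has been measured and on what is new or still open speak of the compounds shown alone.

Measured so far in an ADME assay on HEK293 cells for displacement of a labelled ligand from 5-hydroxytryptamine receptor 7 (Homo sapiens), read by radioligand binding, with a stated time of 1 h; on this read-out lower numbers stand for stronger inhibition and higher numbers for weaker inhibition:
- compound 1, `COc1cccc(N2CCN(CCCCCCN3C(=O)c4ccccc4S3(=O)=O)CC2)c1`, gives 305 nM
- compound 2, `O=C1c2ccccc2S(=O)(=O)N1CCCCCCN1CCN(c2ccccc2)CC1`, gives 192 nM

Going by the values given here, compound 2 has the lowest of the two numbers, but its only neighbour is compound 1, and the step of a 1.6-fold lower number from compound 1 to compound 2 (0.20 log units; within the scatter) lies within the scatter, so the two compounds cannot be told apart on this read-out.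

Compound 3, `O=C1c2ccccc2S(=O)(=O)N1CCCCCCN1CCN(c2ncccn2)CC1`, has not been measured. It differs from compound 2 in one place: pyrimidin-2-yl in place of phenyl on an amine nitrogen in a ring. Among the compounds with values here, the only measured step, a 1.6-fold lower number from compound 1 to compound 2 (0.20 log units; within the scatter), concerns a group on the aromatic ring of compound 1 and not a change of the ring itself, so it gives little guidance for this new change; it shows only that a small edit at that end of the molecule left the number within the scatter.

With nothing closer to go on, compound 3 is expected to stay near compound 2, and the estimated step of a 1.6-fold higher number from compound 2 to compound 3 (0.19 log units; within the scatter) is given a wide range. For compound 3 the estimate in this assay is 300 nM, with a range from 100 nM to 900 nM.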

Compound 3, inhibition constant: 35 nM
The estimate for compound 3 lay 8.6-fold (0.93 log units) above the measured number; the measured number lies below the stated range.
By their numbers in this assay, from the lowest: compound 3; then compounds 2 and 1 (each within the scatter of the next).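

In this assay, this position responds to a change of the ring itself: with pyrimidin-2-yl in place of phenyl on the amine nitrogen, there is a 5.5-fold lower number from compound 2 to compound 3 (0.74 log units; beyond the scatter), whereas the earlier edit of removing the methoxy group stayed within the scatter. Pyrimidin-2-yl in place of 3-methoxyphenyl gives an 8.7-fold lower number from compound 1 to compound 3 (0.94 log units; beyond the scatter), so compound 3 stands apart from both compounds with a carbon-only ring. The two groups in the step from compound 2 to compound 3 have the same heavy-atom count, while the ring goes from carbon only to one with 2 hetero atoms and from 0 to 2 hydrogen-bond acceptors, but no measurement here explains why the number falls.

The compounds shown leave open whether both ring nitrogens are needed, which a pyridin-2-yl group, with a single ring nitrogen, could begin to test. They also leave open whether the gain from pyrimidin-2-yl would hold with a shorter or longer chain between the piperazine-like ring and the other end of the molecule.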